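The compounds below may be only part of what the source reports. "The series", "measured", "known", "first", "only" and "open" are said of these compounds alone.

Measured so far in a functional assay on HepG2 cells (Homo sapiens) for inhibition, read by MTT assay, with a stated time of 24 h; a higher number here means a weaker inhibitor, a lower number a stronger inhibitor:

Compound 1 `CC1(C)[C@H]2CC[C@]1(C)N(Cc1cn(-c3ccc(C#N)cc3)nn1)C(=O)C2` — 50 nM
Compound 2 `CC1(C)[C@H]2CC[C@]1(C)N(Cc1cn(-c3cccc(Cl)c3)nn1)C(=O)C2` — 60 nM
Compound 3 `COc1ccccc1-n1cc(CN2C(=O)C[C@@H]3CC[C@@]2(C)C3(C)C)nn1` — 110 nM

Compound 3 carries the highest of the three numbers. One of its two steps is a 1.8-fold higher number from compound 2 to compound 3 (0.26 log units; within the scatter), and the other is a 2.2-fold higher number from compound 1 to compound 3 (0.34 log units; beyond the scatter), so only the larger of these two steps separates it clearly; compound 1 and compound 2 sit within the scatter of each other, a 1.2-fold higher number from compound 1 to compound 2 (0.08 log units; within the scatter).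

Compound 4 `CC1(C)[C@H]2CC[C@]1(C)N(Cc1cn(-c3ccc(Cl)cc3)nn1)C(=O)C2` is not yet measured. The change from compound 3 is 4-chlorophenyl in place of 2-methoxyphenyl on an aromatic nitrogen. Among the compounds with values here, the steps that bear on it are those in which the group on the aromatic nitrogen is exchanged: the move to 2-methoxyphenyl gave a modest rise, a 2.2-fold higher number from compound 1 to compound 3 (0.34 log units; beyond the scatter), while the exchange of 4-cyanophenyl for 3-chlorophenyl stayed within the scatter, a 1.2-fold higher number from compound 1 to compound 2 (0.08 log units; within the scatter). Returning from 2-methoxyphenyl to a halogenated phenyl is therefore expected to give a modest lowering, roughly the reverse of the observed step, with compound 2 as the nearest reference.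

Compound 4 is expected at 60 nM, range 30 nM to 120 nM, a step of a 1.8-fold lower number from compound 3 to compound 4 (0.26 log units; within the scatter) expected in this assay.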

Compound 4, half-maximal inhibitory concentration: 90 nM
Estimate against measurement, compound 4: 1.5-fold (0.18 log units) below; the range from low to high includes it.
By their numbers in this assay, from the lowest: compounds 1, 2, 4 and 3 (each within the scatter of the next, the first and the last beyond it).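

In this assay, moving chloro within the group on the aromatic nitrogen gives a 1.5-fold higher number from compound 2 to compound 4 (0.18 log units; within the scatter), so 3-chlorophenyl and 4-chlorophenyl are not told apart here. Chloro in place of cyano on an aromatic carbon gives a 1.8-fold higher number from compound 1 to compound 4 (0.26 log units; within the scatter), and 4-chlorophenyl in place of 2-methoxyphenyl gives a 1.2-fold lower number from compound 3 to compound 4 (0.09 log units; within the scatter), which places compound 4 within the scatter of all three earlier compounds and leaves the step from compound 1 to compound 3 as the only one beyond it. No measurement among the data available accounts for any of these steps.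

On these data alone, how a phenyl ring bearing an amine or a carboxylic acid would read on this nitrogen remains open, as does a benzyl group there. The shared core is constant in the compounds shown, so the effect of any change to it also remains open.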